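This account rests on a few compounds, and the source may have more. Where it says the series, first, only, none or still open, it means among the compounds named here.

Working notes on the series in a functional assay on PC-3 cells (Homo sapiens) for antiproliferative activity, read by MTT assay, tested at 5 uM; on this read-out lower numbers stand for a weaker effect and higher numbers for a stronger effect at the one concentration tested.

Three compounds carry numbers. Compound 1 `COc1cc(C2=NN(C(C)=O)C(c3c(Cl)cccc3Cl)O2)cc(OC)c1OC` gives -2.2% in this assay, the lowest of the three; its nearest neighbour is compound 2 `COc1cc(C(=O)N/N=C/c2ccc(C(F)(F)F)cc2)cc(OC)c1OC`, which gives 61.6%, a gap beyond the scatter, and the furthest is compound 3 `COc1cccc(/C=N/NC(=O)c2cc(OC)c(OC)c(OC)c2)c1OC`, which gives 67%, also beyond the scatter. Compounds 2 and 3 are within the scatter of each other, so no order between them is claimed. Compound 1 shares the trimethoxyphenyl motif with both but sits on a different core, and it shows essentially no effect at the tested concentration.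

For the measured compounds named here, no pair of measured compounds differs in a single place, so no step size is established within the set.

Compound 4 `COc1cc(C2=NN(C(C)=O)C(c3ccc(Cl)c(Cl)c3)O2)cc(OC)c1OC` has not yet been measured. It differs from compound 1 by 3,4-dichlorophenyl in place of 2,6-dichlorophenyl on a saturated ring carbon.

Going by the values given here, the expectation for compound 4 rests on compound 1 alone, whose value of -2.2% is the only reading on this core. Among the compounds with values here, with no step of this kind measured, a small upward movement is guessed for compound 4, with a step of a number 12.2 percentage points higher from compound 1 to compound 4 (beyond the scatter) that may well fall within the scatter. Compound 4 is estimated at 10%, in a range from -10% to 40%.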

Compound 4, a percentage reported as inhibition, at one concentration (the size of the read-out at that concentration, not a potency): 26.1%
Compound 4: middle estimate off by 16.1 percentage points, on the low side; low and high end bracket the measured number.
By their numbers in this assay, from the lowest: compound 1; then compound 4; then compounds 2 and 3 (each within the scatter of the next).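

In this assay, 3,4-dichlorophenyl in place of 2,6-dichlorophenyl on the saturated ring carbon gives a number 28.3 percentage points higher from compound 1 to compound 4 (beyond the scatter), the first step measured within the series. The two groups have the same heavy atoms, ring type, donor and acceptor counts and charge, so this position on the shared core responds to where the two chlorines sit on the phenyl ring, and the near-absent effect of compound 1 is not fixed by the core alone. Nothing measured here bears on the reason for this step.

From the compounds shown here alone, with only these two dichlorophenyl groups compared at this carbon, it remains open whether the reading depends on one chlorine, on both together or on their arrangement. Also open, going by these compounds, is how this position would respond to a phenyl ring carrying an amine or a carboxylic acid, or to a longer alkyl chain in place of the ring, and whether any such change would move the reading beyond that of compound 4.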